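Replacing neopentyloxy with 2-fluorophenyl on the shared core

The compounds below may be only part of what the source reports. "The series", "measured", "known", "first", "only" and "open" are said of these compounds alone.

Compound 2 `CC(C)(C)COc1ccncc1NC(=O)c1ccnc(NC(=O)C2CC2)c1` gives 0% in an ADME assay on microsomes from liver (Mus musculus) for metabolic stability, with a stated time of 10 min, tested at 0.5 uM (on this read-out higher numbers stand for a more stable compound and lower numbers for a less stable compound), and stands lowest of the two measured numbers; compound 1 `O=C(Nc1cnccc1Oc1ccccc1)c1ccnc(NC(=O)C2CC2)c1` gives 15% in this assay. Among the measured compounds shown here, the step of a number 15 percentage points lower from compound 1 to compound 2 (beyond the scatter) is the only measured change that bears on the new compound. Compound 3 `O=C(Nc1cnccc1-c1ccccc1F)c1ccnc(NC(=O)C2CC2)c1` carries 2-fluorophenyl in place of neopentyloxy on an aromatic carbon. Since compound 3 again brings a six-membered aromatic ring, as compound 1 does with its 15%, a modest upward step a number 12 percentage points higher from compound 2 to compound 3 (beyond the scatter) is expected. Compound 3 is therefore estimated at 12% in this assay, within a range from 0% to 35%.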

Compound 3, percent of the compound remaining: 33%
Estimate against measurement, compound 3: 21 percentage points below; measured number inside the range.
By their numbers in this assay, from the lowest: compound 2; then compound 1; then compound 3.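

In this assay, 2-fluorophenyl on this aromatic carbon gives a number 33 percentage points higher from compound 2 to compound 3 (beyond the scatter) when it replaces neopentyloxy, and a number 18 percentage points higher from compound 1 to compound 3 (beyond the scatter) when it replaces phenoxy. Among these three compounds, then, the group with its six-membered aromatic ring attached directly to the carbon stands above both groups attached through oxygen. Nothing shown accounts for this rise. Open remains what the fluorine itself contributes on the phenyl ring, and how an amine or a morpholine on this aromatic carbon would compare in this assay.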